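Changing the chain on the aromatic nitrogen: compound 3

This account rests on a few compounds, and the source may have more. Where it says the series, first, only, none or still open, it means among the compounds named here.

Measured compounds:
compound 1 `CC(C)CCn1ccc(N2CCC(c3ccccc3)CC2)c(C#N)c1=O`: 268%
compound 2 `CC(C)Cn1ccc(N2CCC(c3ccccc3)CC2)c(C#N)c1=O`: 316%
compound 3 `N#Cc1c(N2CCC(c3ccccc3)CC2)ccn(CC2CCC2)c1=O`: not yet measured

Going by the values given here, in a functional assay on CHO cells for positive allosteric modulation of metabotropic glutamate receptor 2 (Homo sapiens), with a stated time of 30 min (on this read-out lower numbers stand for smaller maximal responses and higher numbers for larger maximal responses), compound 2 stands highest of the two numbers so far; its nearest neighbour is compound 1, and the single step in hand is a number 48 percentage points higher from compound 1 to compound 2 (beyond the scatter), a move beyond the scatter. Both compounds share the same core and differ only in the chain on the aromatic nitrogen.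

Compound 3 continues at that place: cyclobutyl in place of isopropyl on a saturated chain carbon bound to an aromatic nitrogen. Among the compounds with values here, the only measured step that bears on it is the one from compound 1 to compound 2, which altered the same chain and was large. Within the data shown here, compound 3 keeps a branched chain of similar reach but closes it into a ring, so no measured pair shows this exact change, and the direction is open. Given that the shortening from isobutyl to isopropyl raised the response, a modest reduction or a level result is expected here rather than a further large rise; compound 3 is estimated at 290%, with a range of 230% to 350%, which would mean a step of a number 26 percentage points lower from compound 2 to compound 3 (beyond the scatter).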

Compound 3, largest response reached (Emax), in percent of the reference or control that the assay uses: 269%
Compound 3: the middle estimate sits 21 percentage points above what was measured, within the range that was stated.
By their numbers in this assay, from the lowest: compounds 1 and 3 (each within the scatter of the next); then compound 2.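

In this assay, cyclobutyl in place of isopropyl on a saturated chain carbon bound to an aromatic nitrogen gives a number 47 percentage points lower from compound 2 to compound 3 (beyond the scatter), so this position responds to a change of the group as well as to the change of chain length seen earlier. Cyclobutyl in place of isobutyl at the same place gives a number 1 percentage points higher from compound 1 to compound 3 (within the scatter): an open chain and a four-membered ring of carbon are not separated here, and among these three compounds only the isopropyl of compound 2 stands apart from the others. Nothing at hand accounts for the gap between isopropyl and cyclobutyl or for the match between isobutyl and cyclobutyl.

The compounds shown leave open whether a smaller group, such as ethyl or cyclopropyl, would carry the maximal response further or whether isopropyl marks a peak at this position. They also leave open how a chain holding an ether oxygen, such as methoxyethyl, or an amine would read at this place, since all three groups here consist of carbon only.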